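The compounds below may be only part of what the source reports. "The series", "measured", "known", "first", "only" and "open" are said of these compounds alone.

Of the compounds shown here, two have so far been measured in a functional assay on cells for antagonist activity at Free fatty acid receptor 1 (Homo sapiens), read by TR-FRET and inositol phosphate accumulation, with a stated time of 2 h; on this read-out lower numbers stand for stronger inhibition and higher numbers for weaker inhibition. Compound 1 `CC(=O)Nc1ccc(OCc2cc(C)nc(-c3ccccn3)n2)cc1` gives only a limit in this assay, > 39800 nM, which is the limit of > 39800 nM in this assay, at which 1 of the 2 values shown sits. Compound 2 `OC1CN(c2cc(COc3ccc(F)c(F)c3F)nc(-c3ccccn3)n2)C1` gives 3160 nM in this assay and so stands as the only actual number shown. Compound 3 `Fc1ccc(OCc2cc(OCC3(F)COC3)nc(-c3ccccn3)n2)c(F)c1F` has not been measured; it carries (3-fluorooxetan-3-yl)methoxy in place of 3-hydroxyazetidin-1-yl on an aromatic carbon. Going by the values given here, no step between measured compounds is available, so the change is expected to move the value by a 1.3-fold higher number from compound 2 to compound 3 (0.10 log units; within the scatter), little beyond the usual scatter in either direction. Compound 3 is therefore estimated at 4000 nM in this assay, with a range from 1000 nM to 20000 nM.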

Compound 3, half-maximal inhibitory concentration: 63.1 nM
The estimate for compound 3 lay 63-fold (1.80 log units) above the measured number; the measured number lies below the stated range.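

On an aromatic carbon next to the ring nitrogen, the group matters greatly in this assay: (3-fluorooxetan-3-yl)methoxy in place of 3-hydroxyazetidin-1-yl gives a 50-fold lower number from compound 2 to compound 3 (1.70 log units; beyond the scatter). So this position can strongly change inhibition, which the earlier compounds could not show. No measurement shown gives a reason for this gain.

From the compounds shown here alone, the step changes the ring, the linking oxygen, the fluorine and the hydrogen-bond donor count together, so the part responsible remains open. Also open, going by these compounds, is how a simple methoxy group or a dimethylamino group would behave here.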